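The compounds below may be only part of what the source reports. "The series", "measured", "known", "first", "only" and "open" are said of these compounds alone.

In an ADME assay on MT4 cells (Homo sapiens) for cytotoxicity (on this read-out lower numbers stand for higher toxicity in this test and higher numbers for lower toxicity in this test), compound 3 `Cc1cc(C)cc(S(=O)(=O)n2c(SCC(=O)Nc3ccc(C)cc3Cl)nc3ccc(Cl)cc32)c1` gives > 234000 nM, which is a limit of the assay and not a number. Compound 3 thus stands at the limit of > 234000 nM in this assay, at which 1 of the 3 values shown sits. The other two measured compounds have numbers: compound 1 `Cc1cc(C)cc(Cn2c(SCC(=O)Nc3ccc(C)cc3Cl)nc3ccc(Cl)cc32)c1` gives 79300 nM and compound 2 `Cc1cc(C)cc(S(=O)(=O)n2c(SCC(=O)Nc3ccc(C)cc3Cl)nc3ccccc32)c1` gives 5400 nM.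

Compound 4 `Cc1cc(C)cc(S(=O)(=O)n2c(SCC(=O)Nc3ccc(S(N)(=O)=O)cc3Cl)nc3ccc(Cl)cc32)c1` carries sulfamoyl in place of methyl on an aromatic carbon, para to a large group and meta to a chloro group: sulfamoyl in place of methyl on an aromatic carbon. Neither measured step touches that place. They lie elsewhere in the structure: an at least 2.9-fold higher number from compound 1 to compound 3 (0.46 log units; beyond the scatter) and an at least 43-fold higher number from compound 2 to compound 3 (1.63 log units; beyond the scatter). These steps show that this assay can move widely within this small series, but they give no direct size for the present change.

With only a limit as the starting point, a modest move to a lower number is expected, and another limit reading remains quite possible. The expected step is an at least 1.9-fold lower number from compound 3 to compound 4 (0.29 log units; that floor lies within the scatter). For compound 4 the estimated value is 120000 nM, with an expected range from 25000 nM to 300000 nM.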

Compound 4, half-maximal cytotoxic concentration: 23400 nM
Compound 4: the middle estimate sits 5.1-fold (0.71 log units) above what was measured; measured number outside the range, below it.
By their numbers in this assay, from the lowest: compound 2; then compound 4; then compound 1. At a limit, above all of these: compound 3.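

In this assay, among the compounds shown here, the change from 2-chloro-4-methylphenyl to 2-chloro-4-sulfamoylphenyl gives an at least 10-fold lower number from compound 3 to compound 4 (1.00 log units; beyond the scatter), so this position, untouched by the earlier steps, clearly matters for the read-out. Keeping the chloro group and the (3,5-dimethylphenyl)sulfonyl group of compound 3 therefore does not by itself hold the number at the limit. Compound 3 gives a limit and not a number, so the printed step is only a floor and its full size stays unknown: the limit of > 234000 nM in this assay, at which 1 of the 4 values shown sits.

Only methyl and sulfamoyl are shown at this position; how a carboxylic acid, an amine or a methylsulfonyl group there would read remains open. Also open, as far as these compounds go, is whether sulfamoyl would move the number in the same direction with 3,5-dimethylbenzyl on the aromatic nitrogen or with hydrogen in place of the core chloro group.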